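A few compounds are considered here, and "the series" means these few. Any claim that something is new, unique, unknown or untested is made for them only; others in the source may bear on it.

Measured compounds in an assay on HEK-293T cells for antagonist activity at vitamin D3 receptor (Homo sapiens), read by a luciferase reporter, with a stated time of 24 h; a higher number here means a weaker inhibitor, a lower number a stronger inhibitor:
- compound 1 `CC(C)c1onc(-c2c(Cl)cccc2Cl)c1COc1ccc(-c2nc3ccc(C(=O)O)cc3n2-c2ccc(F)cc2)cc1`: 2410 nM
- compound 2 `CCC(CC)n1c(-c2ccc(OCc3c(-c4c(Cl)cccc4Cl)noc3C(C)C)cc2Cl)nc2ccc(C(=O)O)cc21`: 1010 nM
- compound 3 `CC(C)c1onc(-c2c(Cl)cccc2Cl)c1COc1ccc(-c2nc3ccc(C(=O)O)cc3n2C)cc1Cl`: 2450 nM

Compound 1 stands second highest of the three numbers in this assay. Its nearest neighbour is compound 3, whose value sits within the scatter of that of compound 1, so no order between the two can be read. For the measured compounds named here, compound 2 gives the lowest number of the three, and its value lies beyond the scatter from that of compound 1; no single-point step links compound 2 to compound 1, so only the two values themselves are noted.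

Compound 4 `CCCn1c(-c2ccc(OCc3c(-c4c(Cl)cccc4Cl)noc3C(C)C)cc2)nc2ccc(C(=O)O)cc21` has not yet been measured in this assay. It differs from compound 1 in one place: propyl in place of 4-fluorophenyl on an aromatic nitrogen. Going by the values given here, no step between two measured compounds isolates this change. Compound 3 carries a small alkyl on the same aromatic nitrogen and matches compound 1 within the scatter, while compound 2 carries a branched alkyl there and gives the lower number, though both also carry a chlorine on the central ring that compound 1 lacks. The expected step of a 1.4-fold lower number from compound 1 to compound 4 (0.15 log units; within the scatter) is therefore small, toward a modestly lower number, and may not exceed the scatter. Compound 4 is estimated at 1700 nM, with a range from 700 nM to 4200 nM.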

Compound 4, half-maximal inhibitory concentration: 1400 nM
Compound 4: middle estimate off by 1.2-fold (0.08 log units), on the high side, and the stated range covers the measured number.
By their numbers in this assay, from the lowest: compounds 2, 4, 1 and 3 (each within the scatter of the next, the first and the last beyond it).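

In this assay propyl in place of 4-fluorophenyl on an aromatic nitrogen gives a 1.7-fold lower number from compound 1 to compound 4 (0.24 log units; within the scatter) and is the only step shown that isolates this position. At this position the read-out does not separate the six-membered aromatic ring of carbon bearing fluorine from the three-carbon chain, so in this pair the ring is not needed for a value in this range. No measured property bears on this result, and no cause can be assigned to it.

Still open, going by these compounds, is how an amine or a hydroxyl-bearing chain on the same nitrogen would read, and likewise a longer chain there. For the compounds shown here, the separate contribution of the chlorine on the central ring of compound 2 and compound 3 also remains open, with no step between measured compounds isolating it.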